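The compounds below may be only part of what the source reports. "The series", "measured", "known", "first", "only" and "open" are said of these compounds alone.

Compound 1 `c1ccc(Sc2nn3cc(-c4cc5ccccc5o4)nc3s2)cc1` is the weakest inhibitor of the three compounds measured in a functional assay on HEK293 cells for antagonist activity at proteinase-activated receptor 4 (Homo sapiens), read by FLIPR and calcium flux, with a stated time of 30 min; a lower number here means a stronger inhibitor, a higher number a weaker inhibitor: compound 1 gives 1900 nM. Compound 2 `COc1cc(OCc2cccc(Sc3ccccc3)c2)c2cc(-c3cn4nc(OC)sc4n3)oc2c1` gives 0.89 nM, and compound 3 `COc1cc(OCc2cccc(C#N)c2)c2cc(-c3cn4nc(OC)sc4n3)oc2c1` gives 0.98 nM; both carry a methoxy group on the shared core and a larger substituent on the other ring system, so neither differs from compound 1 in a single place.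

Compound 4 `CC(C)Oc1nn2cc(-c3cc4ccccc4o3)nc2s1` keeps the core of compound 1 and changes one group: isopropoxy in place of phenylsulfanyl on an aromatic carbon. For the measured compounds named here, no measured pair shows this exact exchange. Going by the values given here, the only single-place step recorded, a 1.1-fold higher number from compound 2 to compound 3 (0.04 log units; within the scatter), swaps phenylsulfanyl for cyano on a different aromatic carbon and stays within the scatter, so it offers little guidance here. That compounds 2 and 3 both pair an alkoxy group on the core with far lower numbers than compound 1 hints, weakly, that a small alkoxy group at this position is at least tolerated, but their other differences prevent any firm reading.

The expectation for compound 4 is therefore a modest shift, a 2.4-fold lower number from compound 1 to compound 4 (0.38 log units; beyond the scatter), toward a lower number, though a result indistinguishable from compound 1 is plausible. The estimate for compound 4 in this assay is 800 nM, with a range from 150 nM to 4000 nM.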

Compound 4, half-maximal inhibitory concentration: 760 nM
The estimate for compound 4 lay 1.1-fold (0.02 log units) above the measured number, within the range that was stated.
By their numbers in this assay, from the lowest: compounds 2 and 3 (each within the scatter of the next); then compound 4; then compound 1.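

For the compounds shown here, this step gives the first direct reading of this position: on the aromatic carbon next to the ring nitrogen and next to the ring sulfur, isopropoxy in place of phenylsulfanyl gives a 2.5-fold lower number from compound 1 to compound 4 (0.40 log units; beyond the scatter) in this assay. The step is modest but beyond the scatter, so neither the six-membered aromatic ring nor the sulfur of phenylsulfanyl is needed to keep this level of inhibition, and a group with no ring and fewer heavy atoms gives a somewhat lower number. Nothing available accounts for the shift, which stands as an observation without an established cause.

The exchange alters the linking atom and removes the ring in one move, so the shift cannot be divided between them; phenoxy, which keeps the ring on an oxygen, and isopropylsulfanyl, which keeps the sulfur without the ring, would separate the two. Also open, from the compounds shown here alone, is how this carbon responds to a different kind of group, such as an amine or a longer alkoxy chain, and whether the same exchange would give a similar step on other versions of the core.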